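A New Group on the Amide Nitrogen

The source may hold more compounds than are shown below. What is called first, only, known or untested is meant among the compounds shown, and "the series" means these compounds.

In a functional assay on HCT-116 cells (Homo sapiens) for cytotoxicity, read by MTT assay (on this read-out higher numbers stand for weaker inhibition and lower numbers for stronger inhibition), compound 1 (`CCn1cc(C(=O)Nc2cccc([N+](=O)[O-])c2)c(=O)c2cc(F)c(N3CCNC(C)C3)c(F)c21`) gives 2710 nM and compound 2 (`CCn1cc(C(=O)Nc2ccc(C)c([N+](=O)[O-])c2)c(=O)c2cc(F)c(N3CCNC(C)C3)c(F)c21`) gives the higher of the two numbers (11800 nM). Going by the values given here, only one measured step is available (a 4.4-fold higher number from compound 1 to compound 2 (0.64 log units; beyond the scatter)). It is methyl in place of hydrogen on an aromatic carbon, and it is modest but beyond the scatter. Compound 3 (`CCn1cc(C(=O)Nc2ccc(C(C)=O)cc2)c(=O)c2cc(F)c(N3CCNC(C)C3)c(F)c21`) carries 4-acetylphenyl in place of 4-methyl-3-nitrophenyl on an amide-type nitrogen. Among the compounds with values here, this replaces a whole group, so the single step is only a rough guide, and no measured compound carries 4-acetylphenyl. Compound 2 sits at the top of a very short range, and the methyl it loses went with the higher number in that step. A modest move toward a lower number is therefore expected in this assay (a 2.1-fold lower number from compound 2 to compound 3 (0.33 log units; beyond the scatter)). The estimated value for compound 3 is 5500 nM in a range from 1500 nM to 20000 nM (both ends expected, not measured).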

Compound 3, half-maximal inhibitory concentration: 4600 nM
Compound 3: middle estimate off by 1.2-fold (0.08 log units), on the high side; the measured number falls inside the stated range.
By their numbers in this assay, from the lowest: compounds 1 and 3 (each within the scatter of the next); then compound 2.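

In this assay, the amide-type nitrogen accepts a whole-group exchange without a large shift: 4-acetylphenyl in place of 4-methyl-3-nitrophenyl is a modest step beyond the scatter (a 2.6-fold lower number from compound 2 to compound 3 (0.41 log units; beyond the scatter)). Set against 3-nitrophenyl, the same group gives a step within the scatter (a 1.7-fold higher number from compound 1 to compound 3 (0.23 log units; within the scatter)), so among these three compounds a nitro group on the ring is not required for a number in the range of compound 1, and only compound 2 stands apart. Nothing measured here accounts for these steps.

The compounds leave open whether the acetyl itself contributes or whether other groups on the ring would read the same, such as an amine, a carboxylic acid or a methoxy group. They also leave open how a plain phenyl on the amide-type nitrogen would compare.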